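A few compounds are considered here, and "the series" means these few. Any claim that something is new, unique, unknown or untested is made for them only; others in the source may bear on it.

Compound 1 `C=C1CC[C@@H]2[C@](C)(COC(C)=O)[C@H](OC(C)=O)CC[C@@]2(C)[C@H]1CC(Nc1ccc(S(=O)(=O)Nc2nccs2)cc1)C1=CCOC1=O` carries a 1,3-thiazol-2-yl group on the sulfonamide nitrogen of the shared core. Within the data shown here, in a functional assay on HOP-62 cells (Homo sapiens) for inhibition, read by sulforhodamine B assay, with a stated time of 48 h (on this read-out higher numbers stand for lower toxicity in this test and lower numbers for higher toxicity in this test), compound 1 gives 54700 nM, the highest of the two numbers known here. Among the measured compounds shown here, compound 2 `C=C1CC[C@@H]2[C@](C)(COC(C)=O)[C@H](OC(C)=O)CC[C@@]2(C)[C@H]1CC(Nc1ccc(S(=O)(=O)Nc2ccc(Cl)nn2)cc1)C1=CCOC1=O` gives 6120 nM in this assay, and the only measured step, an 8.9-fold lower number from compound 1 to compound 2 (0.95 log units; beyond the scatter), is modest and beyond the scatter. Compound 3 `C=C1CC[C@@H]2[C@](C)(COC(C)=O)[C@H](OC(C)=O)CC[C@@]2(C)[C@H]1CC(Nc1ccc(S(=O)(=O)Nc2ncccn2)cc1)C1=CCOC1=O` has not yet been measured; it differs from compound 1 in one place: pyrimidin-2-yl in place of 1,3-thiazol-2-yl on a sulfonamide nitrogen. The step to compound 2 bears on this change, since both exchange the five-membered ring for a six-membered aromatic ring with 2 hetero atoms, although compound 3 lacks the chlorine of compound 2. A lower number than compound 1 is therefore expected, but a smaller move than an 8.9-fold lower number from compound 1 to compound 2 (0.95 log units; beyond the scatter). The expected step is a 2.7-fold lower number from compound 1 to compound 3 (0.44 log units; beyond the scatter). Compound 3 is estimated to give 20000 nM in this assay, with a range from 6000 nM to 60000 nM.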

Compound 3, concentration lethal to 50% of the cells: 21500 nM
For compound 3 the middle estimate is 1.1-fold (0.03 log units) below the measured one, and the stated range covers the measured number.
By their numbers in this assay, from the lowest: compound 2; then compound 3; then compound 1.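

In this assay, the step with pyrimidin-2-yl on the sulfonamide nitrogen is a 2.5-fold lower number from compound 1 to compound 3 (0.41 log units; beyond the scatter), so among these compounds both six-membered aromatic rings with 2 hetero atoms give a lower number than 1,3-thiazol-2-yl. These two rings are not interchangeable at this position: the step of a 3.5-fold higher number from compound 2 to compound 3 (0.55 log units; beyond the scatter) is also beyond the scatter, and it changes both the ring and the presence of chlorine. Nothing available here explains either step.

The compounds shown leave open whether the gap between compound 2 and compound 3 follows the chlorine or the ring, a question that a pyridazin-3-yl group without chlorine, or a 6-chloropyrimidin-4-yl group, would bear on. They also leave open how a ring carrying an amine or a carboxylic acid would read at this nitrogen.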